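The source may report more compounds than this note shows. Statements on the series, on what has been measured and on what is new or still open speak of the compounds shown alone.

Compound 3 `Nc1cccc(/C=C2\SC(=O)N(Cc3ccccc3)C2=O)c1` gives 233000 nM in a functional assay on L1210 cells (Mus musculus) for cytotoxicity, read by cell counting, with a stated time of 2 days (a lower number here means a stronger inhibitor, a higher number a weaker inhibitor), the highest of the three numbers shown, though all three lie within the scatter of one another: compound 1 `Nc1cccc(/C=C2\SC(=O)N(Cc3cccc(Cl)c3)C2=O)c1` gives 211000 nM, and compound 2 `Cc1ccc(CN2C(=O)S/C(=C\c3cccc(N)c3)C2=O)cc1` gives 176000 nM. Compound 4 `Nc1cccc(/C=C2\SC(=O)N(Cc3ccc(Cl)cc3)C2=O)c1` has not yet been measured in this assay. It differs from compound 3 by chloro in place of hydrogen on an aromatic carbon. Two measured steps alter the same ring: a 1.1-fold higher number from compound 1 to compound 3 (0.04 log units; within the scatter), and a 1.3-fold higher number from compound 2 to compound 3 (0.12 log units; within the scatter); neither moved the number beyond the scatter. The change to compound 4 is therefore expected to give no step beyond the scatter, a 1.1-fold lower number from compound 3 to compound 4 (0.02 log units; within the scatter). Compound 4 is accordingly estimated at 220000 nM, with a range from 110000 nM to 440000 nM.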

Compound 4, half-maximal inhibitory concentration: 218000 nM
Compound 4: the middle estimate sits 1.0-fold (0.00 log units) above what was measured; low and high end bracket the measured number.
By their numbers in this assay, from the lowest: compounds 2, 1, 4 and 3 (each within the scatter of the next).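

In this assay, chloro on the phenyl ring, para to a large group, gives a 1.1-fold lower number from compound 3 to compound 4 (0.03 log units; within the scatter) and so leaves the number where hydrogen had it. The swap from 3-chlorophenyl to 4-chlorophenyl gives a 1.0-fold higher number from compound 1 to compound 4 (0.01 log units; within the scatter) as well, and chloro in place of methyl gives a 1.2-fold higher number from compound 2 to compound 4 (0.09 log units; within the scatter) here, so neither the place of the chloro nor this exchange separates these compounds. Nothing available explains why the numbers stay so close. The compounds shown leave open whether an amine or a carboxylic acid on this ring would move the number beyond the scatter.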